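A few compounds are considered here, and "the series" means these few. Any claim that something is new, unique, unknown or untested is made for them only; others in the source may bear on it.

Measured compounds in a functional assay on HCT-8 cells (Homo sapiens) for antiproliferative activity, read by MTT assay, with a stated time of 48 h; a higher number here means a weaker inhibitor, a lower number a stronger inhibitor:
- compound 1 `COc1ccc2c(/C=C/C(=O)c3cc(OC)c(OC)c(SC)c3)c[nH]c2c1`: 138 nM
- compound 2 `COc1ccc2c(/C=C/C(=O)c3cc(N)c(OC)c(OC)c3)c[nH]c2c1`: 368 nM
- compound 3 `COc1cc(C(=O)/C=C/c2cn(C)c3ccccc23)cc(SC)c1OC`: 210 nM

On the core of compound 1, the change amino in place of methylsulfanyl on an aromatic carbon gave a 2.7-fold higher number from compound 1 to compound 2 (0.43 log units; beyond the scatter) in this assay. Compound 3 carries a different core; the difference between the two cores is not broken down here. Compound 3 and compound 1 sit within the scatter of each other in this assay, so the two cores are taken as comparable starting points.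

Compound 4 `COc1cc(C(=O)/C=C/c2cn(C)c3ccccc23)cc(N)c1OC` is compound 3 with the same change, (amino in place of methylsulfanyl on an aromatic carbon); the surroundings of the place are the same in both pairs. Going by the values given here, the step from compound 3 to compound 4 is expected to resemble the one seen from compound 1 to compound 2, because a 2.7-fold higher number from compound 1 to compound 2 (0.43 log units; beyond the scatter) is the only precedent for this change. The expected step is a 2.7-fold higher number from compound 3 to compound 4 (0.43 log units; beyond the scatter). Compound 4 is estimated at 570 nM, with a likely range from 260 nM to 1300 nM.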

Compound 4, half-maximal inhibitory concentration: 605 nM
Beside the measured number, compound 4's estimate is 1.1-fold (0.03 log units) below it; the range from low to high includes it.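

In this assay, amino in place of methylsulfanyl gave a 2.9-fold higher number from compound 3 to compound 4 (0.46 log units; beyond the scatter), so the change carries from one core to the other with much the same size: the same change on two cores in this assay, a 2.7-fold higher number (0.43 log units; beyond the scatter) from compound 1 to compound 2 and a 2.9-fold higher number (0.46 log units; beyond the scatter) from compound 3 to compound 4, 1.1-fold (0.03 log units) apart, within the scatter of two such steps.
Going by these compounds alone, with only two pairs in one cell assay, this supports transfer between these two cores alone and gives no general rule for other cores or other cell lines. Nor does it show why the number rises with this change.

The compounds shown carry only methylsulfanyl or amino at this place, so groups such as hydroxyl, dimethylamino or ethylsulfanyl remain open. Also open, as far as these compounds go, is whether any group there would give a lower number than methylsulfanyl on either core.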